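Removing the Sulfonamide Methyl in a Second Core

A few compounds are considered here, and "the series" means these few. Any claim that something is new, unique, unknown or untested is made for them only; others in the source may bear on it.

Of the compounds shown here, three have so far been tested in an ADME assay on SH-SY5Y cells (Homo sapiens) for inhibition, read by MTT assay, with a stated time of 72 h; on this read-out higher numbers stand for weaker inhibition and lower numbers for stronger inhibition. Compound 1 `CN(c1ccccc1)S(=O)(=O)c1ccc2c(c1)sc(=O)n2CCN1CCCCC1` gives 50000 nM, and compound 3 `O=c1sc2cc(S(=O)(=O)Nc3ccccc3)ccc2n1CCN1CCCCC1` gives 17400 nM. The difference between them is hydrogen in place of methyl on a sulfonamide nitrogen, and the compounds differ in this assay by a modest step that lies beyond the scatter. Compound 2 `CN(C)CCn1c(=O)sc2cc(S(=O)(=O)N(C)c3cccc4ccccc34)ccc21` rests on another core; the difference between the two cores is not broken down here. In this assay compound 2 gives 29000 nM. Compound 4 `CN(C)CCn1c(=O)sc2cc(S(=O)(=O)Nc3cccc4ccccc34)ccc21` awaits measurement, and its difference from compound 2 is hydrogen in place of methyl on a sulfonamide nitrogen, the same change at the same place. Within the data shown here, the expected step of a 2.6-fold lower number from compound 2 to compound 4 (0.42 log units; beyond the scatter) rests on the one earlier instance of this change, which gave a 2.9-fold lower number from compound 1 to compound 3 (0.46 log units; beyond the scatter). Compound 4 is therefore estimated at 11000 nM, between 4500 nM and 28000 nM.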

Compound 4, half-maximal inhibitory concentration: 45700 nM
Beside the measured number, compound 4's estimate is 4.2-fold (0.62 log units) below it; measured number outside the range, above it.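

In this assay, hydrogen in place of methyl on a sulfonamide nitrogen gives a 1.6-fold higher number from compound 2 to compound 4 (0.20 log units; within the scatter), so on this core the change has no clear effect. The earlier step therefore did not carry over from one core to the other, and the two steps differ by more than ordinary scatter: the same change on two cores in this assay, a 2.9-fold lower number (0.46 log units; beyond the scatter) from compound 1 to compound 3 and a 1.6-fold higher number (0.20 log units; within the scatter) from compound 2 to compound 4, 4.5-fold (0.66 log units) apart, beyond the scatter of two such steps. This shows that the step seen on one core cannot be assumed on the other, but two pairs of compounds do not show which structural difference between them is responsible.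

Still open, on these data alone, is how an ethyl group on a sulfonamide nitrogen would compare with methyl and hydrogen on either core. Also open, as far as these compounds go, is how the same change would behave on a third core.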